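The source may report more compounds than this note shows. Statements on the series, on what has been measured and on what is new or still open speak of the compounds shown alone.

In a functional assay on HCT-116 cells (Homo sapiens) for antiproliferative activity, read by MTT assay, with a stated time of 48 h (a higher number here means a weaker inhibitor, a lower number a stronger inhibitor), three compounds sharing one core have been measured, and they differ in the group on a saturated chain carbon bound to an amide-type nitrogen. Compound 1 `COc1ccc(CN(C(=O)CSc2nc3ccccc3s2)c2cc(OC)c(OC)c(OC)c2)cc1[N+](=O)[O-]` gives 1280 nM, compound 2 `COc1cc(CN(C(=O)CSc2nc3ccccc3s2)c2cc(OC)c(OC)c(OC)c2)cc(OC)c1OC` gives 65300 nM, and compound 3 `COc1ccc(CN(C(=O)CSc2nc3ccccc3s2)c2cc(OC)c(OC)c(OC)c2)cc1F` gives 1830 nM. Compound 3 therefore holds the middle number of the three, though it sits close to one neighbour and far from the other: a 1.4-fold higher number from compound 1 to compound 3 (0.16 log units; within the scatter), against a 36-fold lower number from compound 2 to compound 3 (1.55 log units; beyond the scatter).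

The next compound, compound 4 `COc1ccc(CN(C(=O)CSc2nc3ccccc3s2)c2cc(OC)c(OC)c(OC)c2)cc1C(F)(F)F`, has trifluoromethyl in place of fluoro on an aromatic carbon. Among the compounds with values here, the nearest precedent is a swap at that same aromatic carbon, fluoro in place of nitro, and that step, a 1.4-fold higher number from compound 1 to compound 3 (0.16 log units; within the scatter), stayed small. The two large steps, a 51-fold higher number from compound 1 to compound 2 (1.71 log units; beyond the scatter) and a 36-fold lower number from compound 2 to compound 3 (1.55 log units; beyond the scatter), bear less directly, since each exchanges the whole 3,4,5-trimethoxyphenyl group rather than one substituent. Within the data shown here, no measured compound carries trifluoromethyl, so its own contribution is unknown. A step beyond the scatter in this assay is not expected, and neither direction is favoured. The expected change is a 1.0-fold lower number from compound 3 to compound 4 (0.01 log units; within the scatter). For compound 4 the estimated value is 1800 nM, with an expected range from 700 nM to 4800 nM.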

Compound 4, half-maximal inhibitory concentration: > 80000 nM
Compound 4: a limit, no number; the forecaster's own chance of this, stated with the estimate: 3%; middle value at least 44-fold (1.64 log units) away from the limit.
By their numbers in this assay, from the lowest: compounds 1 and 3 (each within the scatter of the next); then compound 2. At a limit, above all of these: compound 4.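

In this assay, this aromatic carbon, ortho to a methoxy group, proves far less tolerant than the earlier swap of fluoro for nitro suggested: trifluoromethyl in place of fluoro gives an at least 43-fold higher number from compound 3 to compound 4 (1.64 log units; beyond the scatter), and trifluoromethyl in place of nitro gives an at least 62-fold higher number from compound 1 to compound 4 (1.79 log units; beyond the scatter), so a change of one substituent here now produces a large step, which earlier only exchanges of the whole 3,4,5-trimethoxyphenyl group had done. For compound 4 the reading is a limit of the assay and not a number: the limit of > 80000 nM in this assay, at which 1 of the 4 values shown sits. Against the trimethoxyphenyl compound the comparison gives an at least 1.2-fold higher number from compound 2 to compound 4 (0.08 log units; that floor lies within the scatter), so the limit does not settle how far these two stand apart.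

With only nitro, fluoro and trifluoromethyl shown at this carbon, it remains open whether a chloro, methyl or nitrile group there would stay with the first two or fall with trifluoromethyl. On these data alone, it is also open whether a hydrogen at this carbon, or an amine, would keep the activity of compound 1 and compound 3.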